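Working notes: methoxy to hydroxy steps in the series

A few compounds are considered here, and "the series" means these few. Any claim that something is new, unique, unknown or untested is made for them only; others in the source may bear on it.

Measured so far:
compound 1 `CCc1oc2cc(OC)ccc2c1C(=O)c1ccc(OC)cc1` — 6.2%
compound 2 `CCc1oc2ccc(O)cc2c1C(=O)c1ccc(OC)cc1` — 12.9%
compound 3 `CCc1oc2ccc(O)cc2c1C(=O)c1ccc(O)cc1` — 96.5%

In an assay for inhibition of solute carrier family 22 member 12 (Homo sapiens), read by scintillation counting, with a stated time of 60 min, tested at 50 uM (a lower number here means less inhibition, a higher number more inhibition at the concentration tested (going by the name of the read-out)), compound 1 gives 6.2% and compound 2 gives 12.9%; these two lie within the scatter of each other, and the difference between their two cores is not broken down here. Compound 3 gives 96.5% in this assay. Among the measured compounds shown here, the step from compound 2 to compound 3 is the one informative change in the set: hydrogen in place of methyl on an oxygen on an aromatic ring, which produced a number 83.6 percentage points higher from compound 2 to compound 3 (beyond the scatter).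

Compound 4 `CCc1oc2cc(O)ccc2c1C(=O)c1ccc(OC)cc1` is not yet measured. It is made from compound 1 by the same change, (hydrogen in place of methyl on an oxygen on an aromatic ring), the place being described in the same words in both cases. The expected step is nevertheless not read straight across. Compound 4 carries a hydroxy on its core and a methoxy on the other ring, as compound 2 does, and compound 2 gives only 12.9% in this assay, within the scatter of compound 1. The large step seen between compound 2 and compound 3 came when the remaining methyl was removed, leaving two hydroxy groups; compound 4 keeps one methyl. The step from compound 1 to compound 4 is therefore expected to be small, a number 8.8 percentage points higher from compound 1 to compound 4 (within the scatter), resting on compound 2 giving 12.9%. Compound 4 is estimated at 15% in this assay, with the range 3% to 40% expected to hold most repeats.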

Compound 4, a percentage reported as inhibition, at one concentration (the size of the read-out at that concentration, not a potency): 48.3%
Beside the measured number, compound 4's estimate is 33.3 percentage points below it, and the stated range ends below it.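

In this assay, the change of methoxy to hydroxy gives a number 42.1 percentage points higher from compound 1 to compound 4 (beyond the scatter), and the same change does not carry over from one core to another at a constant size: the same change on two cores in this assay, a number 83.6 percentage points higher (beyond the scatter) from compound 2 to compound 3 and a number 42.1 percentage points higher (beyond the scatter) from compound 1 to compound 4, 41.5 percentage points apart, beyond the scatter of two such steps

Both steps point the same way and both lie beyond the scatter, so on these two cores the direction of the change holds, while its size has to be read for each core separately. This does not show why the size differs, and two pairs give no rule for any further core; each step also rests on a percentage at a single concentration, so neither step says anything about a change in potency.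

The compounds shown leave open whether an amine or a carboxylic acid in place of the hydroxy would give a similar read-out, and whether a longer chain in place of the ethyl group would alter the size of the step on either core. Also open, going by these compounds, is how the methoxy to hydroxy change would behave on a core that differs in some other place, since only these two cases can be set side by side.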